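This account rests on a few compounds, and the source may have more. Where it says the series, first, only, none or still open, it means among the compounds named here.

Compound 1 `Cc1cc(NC(=O)Nc2ccc(O)cc2)c2ccccc2n1` stands only at a limit of the assay: in an ADME assay on Raji cells (Homo sapiens) for cytotoxicity, with a stated time of 72 h (a higher number here means that more compound is needed for the effect, a lower number that less compound is needed), compound 1 gives > 25000 nM, a limit rather than a number. Compound 2 `Cc1cc(NC(=O)Nc2ccccc2N)c2ccccc2n1` is likewise at a limit, giving > 25000 nM in this assay. Among the compounds with values here, the single measured step, a step that the two limits leave unreadable from compound 1 to compound 2, stays unreadable because the limit of > 25000 nM in this assay, at which 2 of the 2 values shown sit, is where both values sit. Compound 3 `Cc1cc(NC(=O)Nc2ccc(C(N)=O)cc2)c2ccccc2n1` differs from compound 1 by carbamoyl in place of hydroxy on an aromatic carbon. No readable step bears on this change, so no shift beyond the scatter is expected in this assay. Compound 3 is therefore expected to give 30000 nM in this assay, within 10000 nM to 100000 nM, most likely again as a limit. That expectation means a step that the limit leaves unreadable from compound 1 to compound 3.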

Compound 3, half-maximal effective concentration: > 25000 nM
Compound 3 gave a limit, no number (the forecaster's own chance of this, stated with the estimate: 80%); the middle value does not contradict the limit.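

No new step can be read between compound 1 and compound 3, because both sit at one limit, as does compound 2: the limit of > 25000 nM in this assay, at which 3 of the 3 values shown sit. The compounds shown leave open what concentration any of them would need for an effect in this assay, and whether either change shifts it.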